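Fluoro in place of hydrogen on compound 2

The source may report more compounds than this note shows. Statements on the series, on what has been measured and on what is new or still open speak of the compounds shown alone.

In a physicochemical assay for lipophilicity, at pH 7.4 (a higher number here means a more lipophilic compound, a lower number a more polar compound), two compounds built on a shared core have been measured so far. Compound 1 `Cc1cc(C(=O)NC(C)C)nn1Cc1cc(Cl)ccc1OCc1ccccc1` gives > 3.7, which is a limit of the assay and not a number. Compound 2 `Cc1cc(C(=O)Nc2ccccc2)nn1Cc1cc(Cl)ccc1OCc1ccccc1` gives > 3.7, which is also a limit and not a number. The evidence so far is therefore (the limit of > 3.7 in this assay, at which 2 of the 2 values shown sit), and compound 2 has no exact place on the scale.

Among the compounds with values here, the only measured step is a step that the two limits leave unreadable from compound 1 to compound 2, with phenyl in place of isopropyl on an amide-type nitrogen. It offers no size to carry forward, and it concerns a different change. Compound 3 `Cc1cc(C(=O)Nc2ccc(F)cc2)nn1Cc1cc(Cl)ccc1OCc1ccccc1` differs from compound 2 by fluoro in place of hydrogen on an aromatic carbon, turning phenyl into 4-fluorophenyl.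

Within the data shown here, no measured step covers this change, so the expectation is only a loose one. The expected step is a step that the limit leaves unreadable from compound 2 to compound 3, small and upward if it can be read at all. In this assay, another reading that is only a limit is the likeliest outcome. The estimate for compound 3 is 4.1, with an expected range from 3.7 to 4.6.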

Compound 3, distribution coefficient: 3
The estimate for compound 3 lay 1.10 log units above the measured number, and the stated range ends above it.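

In this assay, replacing hydrogen with fluoro on an aromatic carbon, para to a large group, turns phenyl into 4-fluorophenyl and gives a number at least 0.70 log units lower from compound 2 to compound 3 (beyond the scatter). Within the data shown here, with 4-fluorophenyl in place of isopropyl on the amide nitrogen, the series shows a number at least 0.70 log units lower from compound 1 to compound 3 (beyond the scatter), and compound 3 is the only one of the three compounds with a number on the scale, 3. Both steps have a direction and a minimum size but no exact size, and the step between compound 1 and compound 2 cannot be read, because the values of those two compounds are limits of the assay and not numbers: the limit of > 3.7 in this assay, at which 2 of the 3 values shown sit.

The compounds shown leave open how far compound 2 really lies from compound 3, and whether this drop belongs to fluoro itself or would also follow from another group in the same place, such as chloro, methoxy, an amine or a carboxylic acid. They also leave open whether fluoro would shift the reading in the same direction on the isopropyl amide or on any other core, since this single pair establishes no wider pattern.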